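This account rests on a few compounds, and the source may have more. Where it says the series, first, only, none or still open, it means among the compounds named here.

Series notes. Compound 1 `CC(C)c1ccc(-n2nc(-c3ccc(C(F)(F)F)cc3O)nc2-c2ccccc2O)cc1` gives 100% in a functional assay on PC-12 cells (Rattus norvegicus) for cytotoxicity, read by MTT assay, with stated times of 2 h and 24 h, tested at 5 uM; a lower number here means a weaker effect, a higher number a stronger effect of the compound at the concentration tested. Compound 2 `COc1ccc(-n2nc(-c3ccc(C(F)(F)F)cc3O)nc2-c2ccccc2O)cc1` gives 86.6%, and compound 3 `Oc1cc(C(F)(F)F)ccc1-c1nc(-c2ccccc2O)n(-c2ccccc2Cl)n1` gives 90.6%. For the measured compounds named here, compound 3 therefore lies within the scatter of both compound 1 and compound 2: the step of a number 9.4 percentage points lower from compound 1 to compound 3 (within the scatter) and the step of a number 4 percentage points higher from compound 2 to compound 3 (within the scatter) are both within the scatter, while only the step of a number 13.4 percentage points lower from compound 1 to compound 2 (beyond the scatter) is beyond it.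

The next compound is compound 4 `COc1cccc(-n2nc(-c3ccc(C(F)(F)F)cc3O)nc2-c2ccccc2O)c1`. Its difference from compound 3 is 3-methoxyphenyl in place of 2-chlorophenyl on an aromatic nitrogen. The step that bears on this most directly is a number 4 percentage points higher from compound 2 to compound 3 (within the scatter), which runs the other way between a methoxyphenyl and a 2-chlorophenyl on the same aromatic nitrogen and stayed within the scatter; the step of a number 9.4 percentage points lower from compound 1 to compound 3 (within the scatter), also a change of the group on that nitrogen, was likewise within the scatter. Going by the values given here, no measured step places a methoxy group at the position it takes in compound 4.

On this basis the change from compound 3 to compound 4 is expected to give a number 2.6 percentage points lower from compound 3 to compound 4 (within the scatter), no step beyond the scatter in either direction. Compound 4 is therefore estimated at 88%, with a range from 74% to 100%.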

Compound 4, a percentage reported as activity, at one concentration (the size of the read-out at that concentration, not a potency): 96.8%
Beside the measured number, compound 4's estimate is 8.8 percentage points below it; measured number inside the range.
By their numbers in this assay, from the lowest: compounds 2, 3, 4 and 1 (each within the scatter of the next, the first and the last beyond it).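

Moving the methoxy group, with 3-methoxyphenyl in place of 4-methoxyphenyl on the aromatic nitrogen, gives a number 10.2 percentage points higher from compound 2 to compound 4 (beyond the scatter) in this assay, so the placing of this one group on the phenyl ring can alone shift the read-out modestly. The other two changes, a number 6.2 percentage points higher from compound 3 to compound 4 (within the scatter) and a number 3.2 percentage points lower from compound 1 to compound 4 (within the scatter), separate nothing, and compound 2 stands apart from compound 1 and compound 4 but not from compound 3 , which goes against any clean split among these aryl groups. Nothing available explains the shift seen with the methoxy group.

Going by these compounds, whether the same sensitivity holds for groups other than methoxy remains open. A phenyl ring carrying an amine or a carboxylic acid on this nitrogen would test whether the read-out can move further from the narrow band seen so far.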